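Aryl change on the aromatic nitrogen: compound 4

This account rests on a few compounds, and the source may have more. Where it says the series, first, only, none or still open, it means among the compounds named here.

Compound 3 `CC(C)c1ccc(-n2nc(C(F)(F)F)cc2CNC(=O)Nc2cccc3[nH]ncc23)cc1` gives 4.1 nM in an assay on CHO-K1 cells for antagonist activity at transient receptor potential cation channel subfamily V member 1 (Homo sapiens), read by FLIPR and calcium flux, with a stated time of 6 min (on this read-out lower numbers stand for stronger inhibition and higher numbers for weaker inhibition), the highest of the three numbers in hand. Compound 2 `O=C(NCc1cc(C(F)(F)F)nn1-c1ccc(C(F)(F)F)cc1)Nc1cccc2[nH]ncc12` gives 3.8 nM, and the two lie within the scatter of each other; compound 1 `O=C(NCc1cc(C(F)(F)F)nn1-c1cccc(C(F)(F)F)c1)Nc1cccc2[nH]ncc12` gives 1.3 nM, and the step of a 3.2-fold higher number from compound 1 to compound 3 (0.50 log units; beyond the scatter) is beyond it.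

Compound 4 `Cc1ccc(-n2nc(C(F)(F)F)cc2CNC(=O)Nc2cccc3[nH]ncc23)cc1C` differs from compound 3 by 3,4-dimethylphenyl in place of 4-isopropylphenyl on an aromatic nitrogen.

Two kinds of measured step bear on this. The step of a 1.1-fold higher number from compound 2 to compound 3 (0.03 log units; within the scatter) shows that exchanging the group on the aromatic carbon of the phenyl barely moves the number. The steps of a 2.9-fold higher number from compound 1 to compound 2 (0.47 log units; beyond the scatter) and a 3.2-fold higher number from compound 1 to compound 3 (0.50 log units; beyond the scatter) show that the identity of the phenyl on the aromatic nitrogen moves the number only modestly among the three compounds measured. Among the compounds with values here, no measured compound carries the 3,4-dimethylphenyl group, so no direct step exists. The expectation is therefore a step of a 1.1-fold higher number from compound 3 to compound 4 (0.04 log units; within the scatter) that stays within or close to the scatter, with no clear direction. Compound 4 is estimated at 4.5 nM in this assay, with a range from 1.5 nM to 13 nM.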

Compound 4, inhibition constant: 2.8 nM
Compound 4: middle estimate off by 1.6-fold (0.21 log units), on the high side; the range from low to high includes it.
By their numbers in this assay, from the lowest: compound 1; then compounds 4, 2 and 3 (each within the scatter of the next).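

In this assay, the 3,4-dimethylphenyl group of compound 4, the only phenyl here that carries two groups, cannot be told apart from either single-group phenyl with its group at the 4-position: a 1.5-fold lower number from compound 3 to compound 4 (0.17 log units; within the scatter) and a 1.4-fold lower number from compound 2 to compound 4 (0.13 log units; within the scatter). The 3-(trifluoromethyl)phenyl of compound 1 still stands apart, with a 2.2-fold higher number from compound 1 to compound 4 (0.33 log units; beyond the scatter), so compound 1 keeps the lowest number of the four, and a second group on this phenyl, with its methyl at the 3-position, does not close that gap. No measurement on hand explains why this position responds in this way to these aryl changes.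

On these data alone, it remains open whether the separation of compound 1 follows the trifluoromethyl group itself or its place on the phenyl, a question that a 3-methylphenyl or a 3-isopropylphenyl compound would address directly. Also open is how the series would read with an amine or a carboxylic acid on this phenyl, since all four groups shown carry only carbon or trifluoromethyl substituents.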